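The compounds below may be only part of what the source reports. "The series", "measured", "known", "first", "only" and "open" are said of these compounds alone.

Measured compounds:
compound 1 `COc1ccc(C2CC(c3ccccc3)=NN2C2=NC(=O)/C(=C3\C(=O)Nc4ccc(Br)cc43)S2)cc1`, which in a functional assay on cells (Cancer cell lines, Homo sapiens) for cytotoxicity, read by sulforhodamine B assay, with a stated time of 48 h (a lower number here means a stronger inhibitor of growth, a higher number a weaker inhibitor of growth), gives 660 nM;
compound 2 `COc1ccc(C2=NN(C3=NC(=O)/C(=C4\C(=O)Nc5ccccc54)S3)C(c3ccc(OC)cc3)C2)cc1`, which in this assay gives 100000 nM;
compound 3 `COc1ccc(C2=NN(C3=NC(=O)/C(=C4\C(=O)Nc5ccc(Br)cc54)S3)C(c3ccc(OC)cc3)C2)cc1`, which in this assay gives 710 nM.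

Compound 3 stands second highest of the three numbers. Its nearest neighbour is compound 1, with a 1.1-fold higher number from compound 1 to compound 3 (0.03 log units; within the scatter); its furthest is compound 2, with a 140-fold lower number from compound 2 to compound 3 (2.15 log units; beyond the scatter). Compound 4 `COc1ccc(C2=NN(C3=NC(=O)/C(=C4\C(=O)Nc5ccc(Cl)cc54)S3)C(c3ccc(OC)cc3)C2)cc1` differs from compound 3 by chloro in place of bromo on an aromatic carbon. Among the compounds with values here, the one measured step that bears on this change is a 140-fold lower number from compound 2 to compound 3 (2.15 log units; beyond the scatter), which shows that the presence or absence of a halogen on that carbon accounts for almost the whole spread among the three compounds, whereas a 1.1-fold higher number from compound 1 to compound 3 (0.03 log units; within the scatter) shows the methoxy change elsewhere to be of no consequence. Within the data shown here, no measured compound carries chloro at that position, so the size of the exchange is not known. Because a 140-fold lower number from compound 2 to compound 3 (2.15 log units; beyond the scatter) is so large, compound 4 is expected to keep most of that gain, with a modest loss estimated as a 1.8-fold higher number from compound 3 to compound 4 (0.26 log units; within the scatter). Compound 4 is therefore estimated at 1300 nM, in the range 400 nM to 5000 nM.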

Compound 4, concentration for total growth inhibition: 710 nM
Beside the measured number, compound 4's estimate is 1.8-fold (0.26 log units) above it, within the range that was stated.
By their numbers in this assay, from the lowest: compounds 1, 3 and 4 (each within the scatter of the next); then compound 2.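

In this assay, chloro in place of bromo on this aromatic carbon gives no change at the digits printed from compound 3 to compound 4 (within the scatter) and so does not separate the two halogens. Chloro in place of hydrogen gives a 140-fold lower number from compound 2 to compound 4 (2.15 log units; beyond the scatter) on the same carbon, a step as large as the one for bromo, so the large drop seen earlier is not particular to bromo and holds for both halogens in this pair of compounds. Nothing available accounts for this result.

The compounds shown leave open whether fluoro, a nitrile or an amine on this carbon would give a number near those of compound 3 and compound 4 or one near that of compound 2. They also leave open whether chloro would match bromo on the core of compound 1, which has phenyl in place of one methoxyphenyl.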